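Cyclopropane sulfonamide series: benzyl to methyl step

The source may report more compounds than this note shows. Statements on the series, on what has been measured and on what is new or still open speak of the compounds shown alone.

Of the compounds shown here, two carry numbers so far. Compound 1 `O=C(O)[C@]1(NS(=O)(=O)c2ccc(-n3cc(Cl)cn3)s2)C[C@@H]1Cc1ccccc1` in an assay on isolated protein for inhibition of A disintegrin and metalloproteinase with thrombospondin motifs 5 (Homo sapiens), tested at 1 uM (on this read-out lower numbers stand for less inhibition and higher numbers for more inhibition at the one concentration tested (going by the name of the read-out)), gives 25%. Compound 2 `CC1(C)C[C@@]1(NS(=O)(=O)c1ccc(-n2cc(Cl)cn2)s1)C(=O)O` in this assay gives 19.6%. Going by the values given here, the gap between these two numbers lies within the usual scatter of repeated measurements, so no order between compound 1 and compound 2 can be read from them, and no step between measured compounds is known. Compound 3 `C[C@H]1C[C@@]1(NS(=O)(=O)c1ccc(-n2cc(Cl)cn2)s1)C(=O)O` has not yet been measured in this assay. Compound 3 differs from compound 1 by hydrogen in place of phenyl on a saturated chain carbon bound to a saturated ring carbon. Since the phenyl of compound 1 is also absent from compound 2, and compound 2 gives 19.6%, the step of a number 7 percentage points lower from compound 1 to compound 3 (within the scatter) is expected to be small, if anything downward, and not beyond the scatter. Compound 3 is expected to reach 18% in this assay, with a range from 5% to 32%.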

Compound 3, a percentage reported as inhibition, at one concentration (the size of the read-out at that concentration, not a potency): 3.5%
Compound 3: middle estimate off by 14.5 percentage points, on the high side; measured number below the stated range.
By their numbers in this assay, from the lowest: compound 3; then compounds 2 and 1 (each within the scatter of the next).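

In this assay, hydrogen in place of phenyl on a saturated chain carbon bound to a saturated ring carbon gives a number 21.5 percentage points lower from compound 1 to compound 3 (beyond the scatter). Going by these compounds alone, this is the first step that can be read beyond the scatter, which the earlier pair could not provide, and it shows that the read-out responds to the benzyl to methyl change at this place, though only as a modest step at a single concentration. No available measurement bears on the reason for this step.

As far as these compounds go, it remains open whether the phenyl ring itself matters or whether a cyclohexyl group or a longer chain in its place would keep the number near that of compound 1 at 25%. A pyridine ring, or a phenyl ring carrying an amine or a carboxylic acid, would test the same place further.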